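This account rests on a few compounds, and the source may have more. Where it says the series, first, only, none or still open, it means among the compounds named here.

Compound 2 `CC(C)c1ccc(-c2nc(SCc3cn(CC(=O)NC(=O)Nc4ccccn4)nn3)nc(Nc3ccccc3F)c2C#N)cc1` is one of two close analogues assessed in a functional assay on MGC-803 cells (Homo sapiens) for inhibition, read by MTT assay, with a stated time of 72 h; a lower number here means a stronger inhibitor, a higher number a weaker inhibitor. In this assay compound 2 gives only a limit, > 64000 nM. Going by the values given here, its one measured neighbour is compound 1 `CC(C)c1ccc(-c2nc(SCc3cn(CC(=O)NC(=O)Nc4ccccn4)nn3)nc(Nc3cccc(Cl)c3)c2C#N)cc1`, which differs from it at a single place. In this assay compound 1 likewise gives only a limit, > 64000 nM. The step that the two limits leave unreadable from compound 1 to compound 2 therefore cannot be sized. Both results sit at the limit of > 64000 nM in this assay, at which 2 of the 2 values shown sit, so neither tells where either compound truly stands. Compound 3 `COc1ccccc1Nc1nc(SCc2cn(CC(=O)NC(=O)Nc3ccccn3)nn2)nc(-c2ccc(C(C)C)cc2)c1C#N` carries methoxy in place of fluoro on an aromatic carbon. Among the compounds with values here, no measured step with a readable size bears on this change, as the only step available is unreadable. The expected step that the limit leaves unreadable from compound 2 to compound 3 is thus one the data cannot size, and the expectation rests on the two limits alone. Compound 3 is accordingly expected to give 90000 nM, within a range from 30000 nM to 300000 nM, and most probably only a limit once more in this assay.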

Compound 3, half-maximal inhibitory concentration: > 64000 nM
Compound 3: no number, only a limit; the forecaster's own chance of this, stated with the estimate: 80%; the middle value lies beyond the limit too.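

Going by these compounds alone, no step among compound 1, compound 2 and compound 3 can be read, as all three results are limits: the limit of > 64000 nM in this assay, at which 3 of the 3 values shown sit. The compounds shown leave open how strongly any of the three inhibits in this assay, and whether the changes among them make any difference there.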